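Imidazole attachment swap on the shared core

A few compounds are considered here, and "the series" means these few. Any claim that something is new, unique, unknown or untested is made for them only; others in the source may bear on it.

For the measured compounds named here, in an ADME assay on microsomes (Mus musculus) for metabolic stability (on this read-out higher numbers stand for fast clearance and lower numbers for slow clearance), compound 2 `CNC(=O)[C@@H]1CCCN1S(=O)(=O)c1ccc(Cl)c(COc2cccc3c(-c4cncn4C)cc(C)nc23)c1Cl` gives 117 mL/min/kg, the lower of the two numbers so far, while compound 1 `CNC(=O)[C@@H]1CCCN1S(=O)(=O)c1ccc(Cl)c(COc2cccc3c(-n4ccnc4)cc(C)nc23)c1Cl` gives 267 mL/min/kg. Going by the values given here, the only measured step, a 2.3-fold lower number from compound 1 to compound 2 (0.36 log units; beyond the scatter), lies modestly beyond the scatter. It accompanies 1-methyl-1H-imidazol-5-yl in place of 1H-imidazol-1-yl on an aromatic carbon.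

Compound 3 `CNC(=O)[C@@H]1CCCN1S(=O)(=O)c1ccc(Cl)c(COc2cccc3c(-c4nccn4C)cc(C)nc23)c1Cl` keeps the shared core and changes only how the methylimidazole is joined: 1-methyl-1H-imidazol-2-yl in place of 1-methyl-1H-imidazol-5-yl on an aromatic carbon. The group stays opposite the ring nitrogen. Among the compounds with values here, no measured pair covers this exact exchange, so the one modest step from compound 1, a 2.3-fold lower number from compound 1 to compound 2 (0.36 log units; beyond the scatter), serves only as a rough guide to size. In this assay a change within the scatter is expected, with no firm direction. The expected step is a 1.1-fold lower number from compound 2 to compound 3 (0.03 log units; within the scatter). Compound 3 is estimated at 110 mL/min/kg, with an expected range of 55 mL/min/kg to 220 mL/min/kg.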

Compound 3, clearance: 917 mL/min/kg
Beside the measured number, compound 3's estimate is 8.3-fold (0.92 log units) below it, and the stated range ends below it.
By their numbers in this assay, from the lowest: compound 2; then compound 1; then compound 3.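

In this assay, for the compounds shown here, at this position opposite the ring nitrogen, the way the methylimidazole is joined counts for more than the first pair could show: the same atoms joined differently give a 7.8-fold higher number from compound 2 to compound 3 (0.89 log units; beyond the scatter) and so the largest step so far. A methyl-bearing imidazole does not by itself bring a lower number, since 1-methyl-1H-imidazol-2-yl in place of 1H-imidazol-1-yl gives a 3.4-fold higher number from compound 1 to compound 3 (0.54 log units; beyond the scatter) and so runs against a 2.3-fold lower number from compound 1 to compound 2 (0.36 log units; beyond the scatter) in direction. Nothing measured here bears on why the two methylimidazole attachments differ so widely.

Open, from the compounds shown here alone, is whether the gap between these attachments survives when the methyl on the imidazole becomes an ethyl. Also open, going by these compounds, is where a pyridin-2-yl or an aminomethyl group at the same position would fall relative to these three compounds.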